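A few compounds are considered here, and "the series" means these few. Any claim that something is new, unique, unknown or untested is made for them only; others in the source may bear on it.

Compound 1 `COCCOCn1cc(C#N)c2c(N)ncnc21`: in a functional assay on KB cells (Homo sapiens) for cytotoxicity (a higher number here means a weaker inhibitor, a lower number a stronger inhibitor), compound 1 gives > 100000 nM, a limit.
Compound 2 `Cn1cc(C(N)=O)c2c(N)ncnc21`: in this assay compound 2 gives > 100000 nM, also a limit.
Compound 3 `CC(C)(C)c1ccc(Cn2cc(C#N)c3c(N)ncnc32)cc1`: in this assay compound 3 gives 3000 nM.

Compound 2 stands at the limit of > 100000 nM in this assay, at which 2 of the 3 values shown sit, and so offers no number, only a ceiling. Going by the values given here, compound 3 is the one measured member that carries a ring on the chain carbon bound to the aromatic nitrogen, and it alone gives a number. Compound 4 `Cc1ccccc1Cn1cc(C(N)=O)c2c(N)ncnc21` differs from compound 2 by 2-methylphenyl in place of hydrogen on a saturated chain carbon bound to an aromatic nitrogen. Among the compounds with values here, no measured pair shows this change, so its size is not known; a step in this assay toward stronger inhibition, beyond the scatter, is expected, though the amide of compound 2 is retained. Compound 4 is estimated at 15000 nM, range 3000 nM to 100000 nM, a step of an at least 6.6-fold lower number from compound 2 to compound 4 (0.82 log units; beyond the scatter) expected.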

Compound 4, half-maximal inhibitory concentration: > 100000 nM
Compound 4 was reported as a limit (the forecaster's own chance of this, stated with the estimate: 30%); at least 6.6-fold (0.82 log units) between middle value and limit.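

Compound 2 and compound 4 both stand as limits, so no step between them can be read: the limit of > 100000 nM in this assay, at which 3 of the 4 values shown sit.

The compounds shown leave open whether 2-methylphenyl in place of hydrogen changes the number at all while the amide is retained.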